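A few compounds are considered here, and "the series" means these few. Any claim that something is new, unique, unknown or untested is made for them only; others in the source may bear on it.

Series on a shared core, read in an ADME assay on LLC-MK2 cells (Macaca mulatta) for cytotoxicity, read by spectrophotometry and crystal violet staining, with a stated time of 4 days; a higher number here means that more compound is tolerated, a lower number that less compound is tolerated. Compound 1 `CC(C)n1ncc2c(C(=O)Nc3ccccc3F)cc(-c3cccnc3)nc21` gives 50000 nM. Compound 2 `CC(C)n1ncc2c(C(=O)Nc3cc(S(N)(=O)=O)ccc3F)cc(-c3cccs3)nc21` gives 25000 nM, which is within the scatter of compound 1, so the two cannot be ordered against each other. For compound 3 `CC(C)n1ncc2c(C(=O)Nc3ccncn3)cc(-c3ccsc3)nc21` the assay reports only a limit, > 200000 nM, and this is the only such limit among the three values, as stated in the limit of > 200000 nM in this assay, at which 1 of the 3 values shown sits. Compound 2 thus carries one of the two numbers shown, with compound 1 a near neighbour and compound 3 outside the numbered range.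

The step to compound 4 `CC(C)n1ncc2c(C(=O)Nc3cc(F)ccc3F)cc(-c3cccs3)nc21` is fluoro in place of sulfamoyl on an aromatic carbon; all else in the structure is kept.

Within the data shown here, no measured step with the same change exists among the three compounds. Compound 4 is expected to give 40000 nM, with a range from 15000 nM to 120000 nM, since compound 1, which also carries a fluorophenyl amide without a sulfamoyl group, gives 50000 nM. The step from compound 2 to compound 4 is expected to be a 1.6-fold higher number from compound 2 to compound 4 (0.20 log units; within the scatter), a shift that stays within the usual scatter.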

Compound 4, half-maximal cytotoxic concentration: 100000 nM
Compound 4: middle estimate off by 2.5-fold (0.40 log units), on the low side; measured number inside the range.
By their numbers in this assay, from the lowest: compounds 2, 1 and 4 (each within the scatter of the next, the first and the last beyond it). At a limit, above all of these: compound 3.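

Fluoro in place of sulfamoyl on this aromatic carbon, meta to a large group and para to a fluoro group, gives in this assay a 4.0-fold higher number from compound 2 to compound 4 (0.60 log units; beyond the scatter), and this is the only step shown between compounds that differ in one place. Among these compounds, with all else kept, more compound is tolerated with fluoro than with sulfamoyl at this position, a direct reading that the earlier compounds, which differ in several places, could not give. No measured property among the data shown accounts for this step.

A single pair cannot separate the loss of sulfamoyl from the arrival of fluoro, and an unsubstituted carbon, an amine, a carboxylic acid or a methoxy group at this position would help to tell the two apart. Going by these compounds, whether the step keeps its size with the other groups seen elsewhere on the shared core also remains open.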